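The compounds below may be only part of what the source reports. "The series", "measured", "known", "first", "only" and "open" are said of these compounds alone.

Compound 2, `CC(C)=CCC[C@]1(C)/C=C/[C@@H](OC(=O)C=C(C)C)[C@](C)(O)/C=C/C(=O)/C(CN(C)C)=C\C1`, gives the lower of the two numbers recorded in a functional assay on A549 cells (Homo sapiens) for antiproliferative activity, read by MTT assay, with a stated time of 48 h; a higher number here means a weaker inhibitor, a lower number a stronger inhibitor: compound 2 gives 590 nM. Among the measured compounds shown here, the only other measured compound, compound 1, `CC(=O)OC/C1=C/C[C@](C)(CCC=C(C)C)/C=C/[C@@H](OC(=O)C=C(C)C)[C@](C)(OC(C)=O)/C=C/C1=O`, gives 15100 nM in this assay, so compound 2 stands well ahead of it, beyond the usual scatter. Compound 3, `CSC(=S)OC/C1=C/C[C@](C)(CCC=C(C)C)/C=C/[C@@H](OC(=O)C=C(C)C)[C@](C)(O)/C=C/C1=O`, has not yet been measured; it differs from compound 2 in one place: a group of 5 heavy atoms (2 carbon, 1 oxygen, 2 sulfur; no ring) in place of a group of 3 heavy atoms (2 carbon, 1 nitrogen; no ring), on a saturated chain carbon bound to a double-bonded ring carbon. For the measured compounds named here, no single-change step between measured compounds is available to calibrate this swap. Compound 1, which carries an oxygen-linked group at the same chain carbon, gives the much weaker value, so a loss of activity is expected here rather than none. Compound 3 is therefore estimated at 3000 nM, with a likely range of 700 nM to 12000 nM. The step from compound 2 to compound 3 is expected to be a 5.1-fold higher number from compound 2 to compound 3 (0.71 log units; beyond the scatter), a weakening beyond the scatter.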

Compound 3, half-maximal inhibitory concentration: 380 nM
For compound 3 the middle estimate is 7.9-fold (0.90 log units) above the measured one; the measured number lies below the stated range.
By their numbers in this assay, from the lowest: compounds 3 and 2 (each within the scatter of the next); then compound 1.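

In this assay, the change is a 1.6-fold lower number from compound 2 to compound 3 (0.19 log units; within the scatter), so on a saturated chain carbon bound to a double-bonded ring carbon, the group of 5 heavy atoms that carries sulfur and no nitrogen stands level with dimethylamino. The pair therefore shows that, on the shared core, a number of this size does not depend on the dimethylamino group at this position. No measured evidence bears on why these two groups give values within the scatter of each other.

Going by these compounds, whether a morpholine ring or a free hydroxyl at the same chain carbon would keep this level remains open. Compound 3 differs in more than one place from compound 1, which gives 15100 nM, so the effect of an oxygen-linked group at this carbon alone also stays unresolved.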